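A Larger Amine at the End of the Chain

The source may report more compounds than this note shows. Statements on the series, on what has been measured and on what is new or still open speak of the compounds shown alone.

Measured compounds:
compound 1 `O=c1cc(-c2ccccc2)oc2cccc(OCCCCCCCN3CCC(O)CC3)c12`: 36 nM
compound 2 `CN(C)CCCCCCOc1ccc2oc(-c3ccccc3)cc(=O)c2c1`: 432 nM

In an assay on isolated protein (Cavia porcellus) with Sigma non-opioid intracellular receptor 1 (Homo sapiens) as the target, read by radioligand binding (a higher number here means a weaker inhibitor, a lower number a stronger inhibitor), compound 2 gives 432 nM, the highest of the two numbers; compound 1 gives 36 nM, and the gap between them lies beyond the scatter. Compound 3 `O=c1cc(-c2ccccc2)oc2ccc(OCCCCCCN3CCNC(CCO)C3)cc12` differs from compound 2 in one place: 3-(2-hydroxyethyl)piperazin-1-yl in place of dimethylamino on a saturated chain carbon, six bonds along the chain from an oxygen on an aromatic ring. Going by the values given here, no measured pair isolates this change. The expectation is a downward step a 3.6-fold lower number from compound 2 to compound 3 (0.56 log units; beyond the scatter), beyond the scatter, since compound 1, which also carries a ring amine bearing a hydroxyl, gives 36 nM. Compound 3 is therefore expected at 120 nM, within 40 nM to 400 nM.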

Compound 3, half-maximal inhibitory concentration: 63 nM
Compound 3: the middle estimate sits 1.9-fold (0.28 log units) above what was measured, and the stated range covers the measured number.
By their numbers in this assay, from the lowest: compounds 1 and 3 (each within the scatter of the next); then compound 2.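

In this assay, 3-(2-hydroxyethyl)piperazin-1-yl in place of dimethylamino on the saturated chain carbon gives a 6.9-fold lower number from compound 2 to compound 3 (0.84 log units; beyond the scatter) and so shows directly that the end of this chain accepts the larger ring amine, with a lower number rather than a loss. No measurement on hand explains the step.

The compounds shown do not separate the ring from its hydroxyethyl group, so plain piperazin-1-yl or morpholine could give a different result. On these data alone, how a longer chain would act with this amine also stays open.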